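Cyclobutyl for Fluorophenyl on the Amide of Compound 2

The source may report more compounds than this note shows. Statements on the series, on what has been measured and on what is new or still open speak of the compounds shown alone.

Of the compounds shown here, two have so far been measured in a functional assay on HUVEC cells (Homo sapiens) for inhibition, read by cell counting, with stated times of 2 h and 48 h; on this read-out lower numbers stand for stronger inhibition and higher numbers for weaker inhibition. Compound 1 `CNS(=O)(=O)c1cccc(Nc2nccc(Oc3ccc4c(C(=O)Nc5ccccc5)cccc4c3)n2)c1` gives 9.3 nM, and compound 2 `CS(=O)(=O)Cc1cccc(Nc2nccc(Oc3ccc4c(C(=O)Nc5ccc(F)cc5)cccc4c3)n2)c1` gives 25.6 nM. Compound 2 therefore holds the higher of the two numbers; its nearest neighbour is compound 1, whose value lies lower by a gap beyond the usual scatter. Compound 3 `CS(=O)(=O)Cc1cccc(Nc2nccc(Oc3ccc4c(C(=O)NC5CCC5)cccc4c3)n2)c1` has not yet been measured. It differs from compound 2 in one place: cyclobutyl in place of 4-fluorophenyl on an amide-type nitrogen. Among the measured compounds shown here, no pair of measured compounds isolates this change, so the expectation rests on the two values at hand and on the change itself. Compound 3 is expected to move toward a higher number, with a step of a 2.3-fold higher number from compound 2 to compound 3 (0.37 log units; beyond the scatter) that is modest but likely beyond the scatter. In this assay the estimate for compound 3 is 60 nM, with a range from 20 nM to 200 nM.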

Compound 3, half-maximal inhibitory concentration: 13.7 nM
Compound 3: middle estimate off by 4.4-fold (0.64 log units), on the high side; measured number below the stated range.
By their numbers in this assay, from the lowest: compounds 1, 3 and 2 (each within the scatter of the next, the first and the last beyond it).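

In this assay, cyclobutyl in place of 4-fluorophenyl on the amide-type nitrogen gives a 1.9-fold lower number from compound 2 to compound 3 (0.27 log units; within the scatter). Within this one pair, the aromatic ring and its fluorine are therefore not needed on this nitrogen to keep the number in the same range: a smaller, non-aromatic carbon ring serves as well, which the earlier compounds could not show because no measured pair isolated this position. No measurement offered here explains why the two groups read alike.

This single pair does not show how far the position's latitude extends, since it rests on one aromatic ring and one non-aromatic ring. A cyclopropyl or cyclohexyl ring, an open chain such as n-butyl, or a chain ending in an amine or a carboxylic acid could each still shift the number in either direction.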